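From pyrazin-2-yl to pyrimidin-4-yl on a shared core

The source may hold more compounds than are shown below. What is called first, only, known or untested is meant among the compounds shown, and "the series" means these compounds.

Compound 1 `CC(C)OC(=O)c1sc(Nc2ncccn2)nc1-c1ccccn1` – 50000 nM
Compound 2 `CCOC(=O)c1sc(Nc2ncccn2)nc1-c1ccncn1` – 40800 nM
Compound 3 `CC(C)OC(=O)c1sc(Nc2ncccn2)nc1-c1cnccn1` – 50000 nM

In a toxicity assay on THLE-2 cells (Homo sapiens) for cytotoxicity, read by MTT assay, with a stated time of 72 h (a higher number here means that more compound is tolerated, a lower number that less compound is tolerated), compound 3 gives 50000 nM and stands level with compound 1, while compound 2 lies within the usual scatter of both, so these three numbers do not separate.

The next compound to be tested is compound 4 `CC(C)OC(=O)c1sc(Nc2ncccn2)nc1-c1ccncn1` with the isopropoxycarbonyl group of compound 3 kept and one ring exchanged: pyrimidin-4-yl in place of pyrazin-2-yl on an aromatic carbon. The two compounds have the same atoms, joined differently.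

Among the measured compounds shown here, the only measured step that bears directly on this swap is no change at the digits printed from compound 1 to compound 3 (within the scatter) when pyrazin-2-yl took the place of pyridin-2-yl on that same carbon. Compound 2 (40800 nM) already carries pyrimidin-4-yl at this place, although with a different ester, and its number lies close to the others. Three compounds are a thin basis, but nothing in them points to a real shift in this assay in either direction.

The expected step is none beyond the scatter (a 1.1-fold lower number from compound 3 to compound 4 (0.05 log units; within the scatter)). For compound 4 the estimated value is 45000 nM with an expected range from 28000 nM to 62000 nM in this test.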

Compound 4, half-maximal cytotoxic concentration: 46200 nM
The estimate for compound 4 lay 1.0-fold (0.01 log units) below the measured number; measured number inside the range.
By their numbers in this assay, from the lowest: compounds 2, 4, 1 and 3 (each within the scatter of the next).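

With the isopropoxycarbonyl group held fixed, this assay gives a 1.1-fold lower number from compound 3 to compound 4 (0.03 log units; within the scatter) for pyrimidin-4-yl in place of pyrazin-2-yl, and a 1.1-fold lower number from compound 1 to compound 4 (0.03 log units; within the scatter) for pyrimidin-4-yl in place of pyridin-2-yl, so three different rings at this position on one ester now lie within the scatter of each other. Among the compounds shown here, compound 4 also allows the first comparison of compound 2 with a compound that differs in only one place: methyl in place of hydrogen on the saturated chain carbon bound to the ester oxygen gives a 1.1-fold higher number from compound 2 to compound 4 (0.05 log units; within the scatter), so with pyrimidin-4-yl held fixed, this change to the ester does not separate the two numbers either. No measurement at hand gives a reason why these numbers stay together.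

Going by these compounds, all four compounds carry a nitrogen-containing six-membered aromatic ring at this position and an ester on the neighbouring ring atom, so it remains open whether a plain phenyl ring there, or a carboxylic acid or an amide in place of the ester, would stay in the same range. These numbers also come from a single cell test, so they leave open whether other cell types would respond in the same way.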